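The source may hold more compounds than are shown below. What is called first, only, known or untested is meant among the compounds shown, and "the series" means these compounds.

Measured so far in a functional assay on the whole organism (Tail, strain ICR) with Mus musculus as the target, in the tail flick test, with a stated time of 30 min, at a dose of 25 umol/kg by the oral route; on this read-out higher numbers stand for a stronger effect at the one dose given and lower numbers for a weaker effect:
Compound 1 `NC(=O)CC[C@H](NC(=O)CN(c1ncnc2c1ncn2C1CCCCO1)C1CC1)C(=O)OCc1ccccc1` gives 47%.
Compound 2 `O=C(CN(c1ncnc2c1ncn2C1CCCCO1)C1CC1)N[C@@H](CC(=O)OCc1ccccc1)C(=O)OCc1ccccc1` gives 31.8%.

Of these two numbers compound 2 holds the lower one, with compound 1 standing above it by a margin beyond the scatter. Compound 3 `CC(C)(C)OC(=O)NCCCC[C@H](NC(=O)CN(c1ncnc2c1ncn2C1CCCCO1)C1CC1)C(=O)OCc1ccccc1` has not yet been measured. It differs from compound 2 in one place: 3-((tert-butoxycarbonyl)amino)propyl in place of benzyloxycarbonyl on a saturated chain carbon, two bonds along the chain from an amide-type nitrogen and a carbonyl carbon. Going by the values given here, only one measured step touches this place on the chain, a number 15.2 percentage points lower from compound 1 to compound 2 (beyond the scatter), and there the group that entered was the very benzyloxycarbonyl group that now leaves. That step was modest and pointed downward. The change toward compound 3 removes the same group again, but nothing measured shows how the entering 3-((tert-butoxycarbonyl)amino)propyl group behaves on its own, so the direction rests on a single comparison. A step back upward of roughly the earlier size is therefore expected, with wide uncertainty, as a number 10.2 percentage points higher from compound 2 to compound 3 (beyond the scatter). Compound 3 is accordingly estimated at 42%, within a range from 18% to 66% in this assay.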

Compound 3, a percentage reported as activity, at one dose (the size of the read-out at that dose, not a potency): 18.3%
Beside the measured number, compound 3's estimate is 23.7 percentage points above it; low and high end bracket the measured number.
By their numbers in this assay, from the lowest: compound 3; then compound 2; then compound 1.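

Replacing benzyloxycarbonyl with 3-((tert-butoxycarbonyl)amino)propyl on the saturated chain carbon, in this assay, gives a number 13.5 percentage points lower from compound 2 to compound 3 (beyond the scatter) and so shows that removing benzyloxycarbonyl does not by itself bring the effect back at this position. Measured against the carbamoyl-ended side chain, the change to 2-((tert-butoxycarbonyl)amino)ethyl gives a number 28.7 percentage points lower from compound 1 to compound 3 (beyond the scatter) and is the largest step among these compounds, which leaves compound 1 highest of the three and compound 3 lowest. Nothing available explains this order, so the fall cannot be tied to any feature of the entering group.

The entering side chain brings a longer chain and a tert-butoxycarbonyl-capped nitrogen together, so these compounds cannot separate what each part contributes. A free amine at the end of the 4-butyl chain would help to separate them, while a free carboxylic acid in place of benzyloxycarbonyl would show whether the ester matters at this position.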